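Neopentyl to cyclopentyl on the ring amine nitrogen

A few compounds are considered here, and "the series" means these few. Any claim that something is new, unique, unknown or untested is made for them only; others in the source may bear on it.

Within the data shown here, in an in vitro ADME assay on microsomes from liver (Homo sapiens) for pharmacokinetics (on this read-out higher numbers stand for fast clearance and lower numbers for slow clearance), compound 3 `Cc1ccc(S(=O)(=O)N2C=CNC(=O)[C@H]2CC(=O)N[C@H]2CCN(CC(C)(C)C)CC2(C)C)cc1` gives 405 mL.min-1.g-1, the only actual number so far. Compound 1 `CCN1CC[C@H](NC(=O)C[C@@H]2C(=O)NC=CN2S(=O)(=O)c2ccc(C)cc2)C(C)(C)C1` reads < 50 mL.min-1.g-1, which is a limit of the assay. Compound 2 `CCCN1CC[C@H](NC(=O)C[C@@H]2C(=O)NC=CN2S(=O)(=O)c2ccc(C)cc2)C(C)(C)C1` reads < 50 mL.min-1.g-1, which is also a limit of the assay. Compound 3 therefore stands highest of the three, as both of its measured steps show: an at least 8.1-fold higher number from compound 1 to compound 3 (0.90 log units; beyond the scatter) and an at least 8.1-fold higher number from compound 2 to compound 3 (0.90 log units; beyond the scatter). The remaining step, a step that the two limits leave unreadable from compound 1 to compound 2, adds nothing to the comparison.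

The next structure is compound 4 `Cc1ccc(S(=O)(=O)N2C=CNC(=O)[C@H]2CC(=O)N[C@H]2CCN(C3CCCC3)CC2(C)C)cc1`, with cyclopentyl in place of neopentyl on an amine nitrogen in a ring. Among the measured compounds shown here, no measured step exchanges neopentyl for a ring, so the comparison is indirect. Tert-butyl is the group that enters in an at least 8.1-fold higher number from compound 1 to compound 3 (0.90 log units; beyond the scatter), and it leaves again with the neopentyl here. A fall in the number beyond the scatter is therefore expected, though probably not all the way to the limit. The expected size is a 3.4-fold lower number from compound 3 to compound 4 (0.53 log units; beyond the scatter). Compound 4 is estimated at 120 mL.min-1.g-1, with an expected range of 35 mL.min-1.g-1 to 350 mL.min-1.g-1.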

Compound 4, intrinsic clearance in microsomes: < 14 mL.min-1.g-1
Compound 4 ended at the assay's limit (the forecaster's own chance of this, stated with the estimate: 30%); at least 8.5-fold (0.93 log units) between middle value and limit.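

In this assay, the exchange of neopentyl for cyclopentyl on the amine nitrogen in a ring gives an at least 28-fold lower number from compound 3 to compound 4 (1.46 log units; beyond the scatter), although the two groups have the same count of heavy atoms, all carbon, and neither has a hydrogen-bond donor or acceptor; the printed difference between them is the one five-membered non-aromatic ring of carbon only. Compound 4 reads < 14 mL.min-1.g-1, which is a limit of the assay. With only ethyl, propyl and neopentyl, the high number could have been read as following the size of the group on this nitrogen, but cyclopentyl goes against that reading: the count of heavy atoms alone does not set the number, and the shape of the group matters at this position.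

The steps from compound 1 and from compound 2 to compound 4 cannot be read, since both ends of each are limits, so the order among these three compounds stays open. The compounds shown also leave open whether cyclobutyl, cyclohexyl, a tetrahydropyranyl ring or an open-chain isopropyl on this nitrogen would stay as low as cyclopentyl or move towards neopentyl.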